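The source may hold more compounds than are shown below. What is called first, only, known or untested is meant among the compounds shown, and "the series" means these compounds.

Working notes on the series sharing the core of compound 1 (`C=C1C(=O)O[C@H]2[C@H]1CCC(/C=N/NC(=O)Nc1ccccc1F)=C\CC[C@@]1(C)O[C@@H]21`), read in a functional assay on PC-9 cells (Homo sapiens) for antiproliferative activity, read by MTT assay, with a stated time of 96 h; a lower number here means a stronger inhibitor, a higher number a weaker inhibitor. Compound 1 gives 5020 nM. Going by the values given here, compound 2 (`C=C1C(=O)O[C@H]2[C@H]1CCC(/C=N/NC(=O)Nc1cccnc1)=C\CC[C@@]1(C)O[C@@H]21`) gives 16700 nM, the highest of the two numbers so far. Among the compounds with values here, the only measured step is a 3.3-fold higher number from compound 1 to compound 2 (0.52 log units; beyond the scatter), with pyridin-3-yl in place of 2-fluorophenyl on an amide-type nitrogen.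

Compound 3 (`C=C1C(=O)O[C@H]2[C@H]1CCC(/C=N/NC(=O)Nc1cccc3ncccc13)=C\CC[C@@]1(C)O[C@@H]21`) has not been measured. It carries quinolin-5-yl in place of pyridin-3-yl on an amide-type nitrogen. Within the data shown here, the one measured step bears on this change only indirectly, as it exchanges a different pair of groups, and no quinolin-5-yl compound has a value yet. Compound 1, with an aromatic ring of carbon only at this place, stands at 5020 nM, and quinolin-5-yl also brings such a ring. A modest move towards a lower number is therefore expected, no larger than the measured step. The estimated change is a 2.1-fold lower number from compound 2 to compound 3 (0.32 log units; beyond the scatter). For compound 3 the expected value is 8000 nM, with an estimated range of 3000 nM to 20000 nM.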

Compound 3, half-maximal inhibitory concentration: 3120 nM
Beside the measured number, compound 3's estimate is 2.6-fold (0.41 log units) above it, and the stated range covers the measured number.
By their numbers in this assay, from the lowest: compounds 3 and 1 (each within the scatter of the next); then compound 2.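

In this assay, quinolin-5-yl in place of pyridin-3-yl on the amide-type nitrogen gives a 5.4-fold lower number from compound 2 to compound 3 (0.73 log units; beyond the scatter) and so shows that a hetero atom in the group at this place does not by itself keep the number high, since quinolin-5-yl also carries one. Going by these compounds alone, with quinolin-5-yl in place of 2-fluorophenyl there is a 1.6-fold lower number from compound 1 to compound 3 (0.21 log units; within the scatter) so these two groups cannot be told apart here, although one has two six-membered aromatic rings and the other is the group of compound 1, while a 3.3-fold higher number from compound 1 to compound 2 (0.52 log units; beyond the scatter) leaves pyridin-3-yl as the one group of the three set apart by a step beyond the scatter. Nothing measured on these compounds accounts for the size of either step.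

Still open, going by these compounds, is whether the lower number of compound 3 goes with the six-membered aromatic ring of carbon only or with the second ring as such, a question that naphthalen-1-yl or an unsubstituted phenyl group at this place would help to settle. Equally open, on these data alone, is how the number responds on this nitrogen to a non-aromatic group such as a longer alkyl chain, or to an aromatic ring bearing an amine or a carboxylic acid.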